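The compounds below may be only part of what the source reports. "The series", "measured", "known", "first", "only" and "open" are said of these compounds alone.

Measured in an ADME assay on microsomes from liver (Homo sapiens) for metabolic stability, read by LC-MS, with a stated time of 30 min, tested at 1 uM; a lower number here means slower removal, a higher number faster removal of the compound:
- Compound 1 `C[C@@H](c1c[nH]c2ncccc12)c1nnc2ccc(-c3cnn(C)c3)nn12`: < 7.6 mL.min-1.g-1 (a limit of the assay, not a number)
- Compound 2 `COc1ccc(-c2ccc3nnc([C@@H](C)c4ccc5ncccc5c4)n3n2)cc1F`: 281 mL.min-1.g-1

Within the data shown here, compound 2, at 281 mL.min-1.g-1, holds the only true number so far, so no measured step between related compounds is available as a guide. Compound 3 `Cc1cccc(-c2ccc3nnc([C@@H](C)c4ccc5ncccc5c4)n3n2)c1` keeps the rest of compound 2 but carries 3-methylphenyl in place of 3-fluoro-4-methoxyphenyl on an aromatic carbon. The expected change, a 1.3-fold lower number from compound 2 to compound 3 (0.11 log units; within the scatter), is small and stays within the usual scatter of this assay, so no firm direction is claimed. For compound 3 the estimated value is 220 mL.min-1.g-1, with an expected range from 90 mL.min-1.g-1 to 500 mL.min-1.g-1.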

Compound 3, intrinsic clearance in microsomes: 81.8 mL.min-1.g-1
Estimate against measurement, compound 3: 2.7-fold (0.43 log units) above, outside the stated range (below it).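

In this assay, replacing 3-fluoro-4-methoxyphenyl with 3-methylphenyl gives a 3.4-fold lower number from compound 2 to compound 3 (0.54 log units; beyond the scatter). Among these compounds, this is the first measured sign that the aryl group on this aromatic carbon alone can shift the rate of removal by more than the usual scatter, while the rest of the molecule stays the same. Nothing measured here accounts for the size or direction of this step.

As far as these compounds go, the oxygen, the fluorine and the methyl group all change in one step, so their separate contributions remain unknown. From the compounds shown here alone, whether plain phenyl, 3-fluorophenyl, 4-methoxyphenyl or a ring bearing an amine would follow the same trend also remains open.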